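This account rests on a few compounds, and the source may have more. Where it says the series, first, only, none or still open, it means among the compounds named here.

Measured so far:
compound 1 `c1cc(-c2nccs2)c2c(c1)C(c1ncc[nH]1)CC2` — 426 nM in a functional assay on CHO cells for agonist activity at Alpha-1A adrenergic receptor (Homo sapiens), read by FLIPR and calcium flux; a higher number here means that more compound is needed for the effect, a lower number that less compound is needed
compound 2 `Clc1ccc2c(c1-c1ccn[nH]1)CCC2c1ncc[nH]1` — 322 nM in this assay

In this assay compound 1 stands alongside compound 2: the two numbers lie within the usual scatter of each other, so neither can be placed ahead of the other. Compound 3 `Cn1cc(-c2cccc3c2CCC3c2ncc[nH]2)cn1` has not yet been measured. It differs from compound 1 in one place: 1-methyl-1H-pyrazol-4-yl in place of 1,3-thiazol-2-yl on an aromatic carbon. For the measured compounds named here, no measured pair shows a change of this kind, so there is no step to lean on. Swapping one small aromatic ring for another of similar make-up is expected to shift the number only modestly, with a 1.2-fold higher number from compound 1 to compound 3 (0.07 log units; within the scatter) expected to remain within the scatter. For compound 3 the estimate is 500 nM, with a range from 200 nM to 1500 nM.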

Compound 3, half-maximal effective concentration: > 2900 nM
Compound 3: no number, only a limit (the forecaster's own chance of this, stated with the estimate: 5%); middle value at least 5.8-fold (0.76 log units) away from the limit.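

This position is sensitive to which five-membered aromatic ring it carries: 1-methyl-1H-pyrazol-4-yl in place of 1,3-thiazol-2-yl gives an at least 6.8-fold higher number from compound 1 to compound 3 (0.83 log units; beyond the scatter) in this assay. Both rings count the same hetero atoms, donors and acceptors, so these counts alone do not predict the outcome here. For compound 3 the result is a limit and not a number, so the full size of the step stays unknown: the limit of > 2900 nM in this assay, at which 1 of the 3 values shown sits.

The compounds shown leave open whether the methyl group or the pyrazole ring itself accounts for the step. They also say nothing about a simple amine or a carboxylic acid at this position.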